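Cytotoxicity on CHO cells in a rhodanine-type benzylidene series

This account rests on a few compounds, and the source may have more. Where it says the series, first, only, none or still open, it means among the compounds named here.

Measured so far:
compound 1 `O=C1/C(=C/c2ccc([N+](=O)[O-])cc2)S/C(=N\c2ccccc2)N1Cc1ccco1` — "not determined" (no result reported)
compound 2 `O=C1/C(=C/c2ccccn2)S/C(=N\c2ccccc2)N1Cc1ccco1` — > 400000 nM

In a toxicity assay on CHO cells (Cricetulus griseus) for cytotoxicity, read by MTT assay, with a stated time of 48 h (on this read-out lower numbers stand for stronger inhibition and higher numbers for weaker inhibition), compound 1 gives "not determined" (no result reported). Compound 2 reaches only a limit of this assay, > 400000 nM. Within the numbers shown, compound 2 therefore stands at the limit of > 400000 nM in this assay, at which 1 of the 2 values shown sits, and no single value sits beside it for comparison. Among the measured compounds shown here, no step between two measured compounds is available in this assay.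

Compound 3 `COc1ccc(/C=C2\S/C(=N\c3ccccc3)N(Cc3ccco3)C2=O)cc1` is the next member. It differs from compound 2 in one place: 4-methoxyphenyl in place of pyridin-2-yl on a double-bonded chain carbon bound to a double-bonded ring carbon.

With compound 2 sitting at the limit, no direction can be read from a measured step. The step from compound 2 to compound 3 is expected to be none beyond the scatter, a number no higher from compound 2 to compound 3 (the limit leaves the size open), since compound 2 gives > 400000 nM and a limit cannot rise further. Compound 3 is estimated at 400000 nM, within 100000 nM to 1500000 nM, and most likely it will again be reported only as a limit.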

Compound 3, half-maximal inhibitory concentration: > 400000 nM
Compound 3: a limit, no number (the forecaster's own chance of this, stated with the estimate: 75%); the middle value lies on the limit itself.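

Compound 2 and compound 3 each stand only at a limit in this assay, not at a number, so no new step can be read between them. The compounds shown leave open whether 4-methoxyphenyl and pyridin-2-yl differ at all in this assay.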